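Aryl swap on the amine nitrogen: compound 3 to compound 4

This account rests on a few compounds, and the source may have more. Where it says the series, first, only, none or still open, it means among the compounds named here.

Compound 1 `Fc1cccc(Nc2nc(-c3cccc(F)c3)nc3ccc(F)cc23)c1` gives 49600 nM in a functional assay on U2OS cells (Homo sapiens) for cytotoxicity, read by MTT assay, with a stated time of 48 h; a higher number here means a weaker inhibitor, a lower number a stronger inhibitor.
Compound 2 `Fc1cccc(-c2nc(Nc3ccccc3Cl)c3cc(F)ccc3n2)c1` gives > 50000 nM in this assay, a limit and not a number.
Compound 3 `Fc1cccc(-c2nc(Nc3ccc(Br)cc3)c3cc(F)ccc3n2)c1` gives > 50000 nM in this assay, a limit and not a number.

Compound 3 stands at the limit of > 50000 nM in this assay, at which 2 of the 3 values shown sit, so its place among the three is not readable. Compound 4 `Oc1ccccc1Nc1nc(-c2cccc(F)c2)nc2ccc(F)cc12` differs from compound 3 by 2-hydroxyphenyl in place of 4-bromophenyl on a nitrogen on an aromatic ring. Among the compounds with values here, the steps that bear on this change are the earlier swaps of the aryl on the same nitrogen: a number no lower from compound 1 to compound 3 (the limit leaves the size open), a step that the two limits leave unreadable from compound 2 to compound 3 and a number no lower from compound 1 to compound 2 (the limit leaves the size open). None of them has a readable size, and every aryl tried so far has left the value at or beside the limit. The expected step is therefore a number no higher from compound 3 to compound 4 (the limit leaves the size open), nothing beyond the scatter. Compound 4 is estimated at 50000 nM, within 20000 nM to 100000 nM, most likely again reported only as a limit.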

Compound 4, half-maximal inhibitory concentration: 41400 nM
Compound 4: middle estimate off by 1.2-fold (0.08 log units), on the high side; low and high end bracket the measured number.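

Within the data shown here, with 2-hydroxyphenyl on this nitrogen, the series gains a second readable number, and the one step of fixed size stays within the scatter: a 1.2-fold lower number from compound 1 to compound 4 (0.08 log units; within the scatter). The other two steps have only a floor: an at least 1.2-fold lower number from compound 3 to compound 4 (0.08 log units; that floor lies within the scatter) and an at least 1.2-fold lower number from compound 2 to compound 4 (0.08 log units; that floor lies within the scatter). Their full size, like that of the earlier steps among these compounds, cannot be read because compound 2 and compound 3 are limits: the limit of > 50000 nM in this assay, at which 2 of the 4 values shown sit.

Going by these compounds, whether any aryl on this nitrogen moves the value beyond the scatter stays open. So does the effect of an amine or a carboxylic acid on that aryl.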